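Removing the nitrile from compound 2: what to expect

A few compounds are considered here, and "the series" means these few. Any claim that something is new, unique, unknown or untested is made for them only; others in the source may bear on it.

Measured compounds:
compound 1 `COc1ccc(/C=C\C(=O)O)c(OCc2cn(-c3ccc(NC(=O)c4ccccc4)cc3)nn2)c1CC=C(C)C` gives 16400 nM
compound 2 `COc1ccc(/C=C\C(=O)O)c(OCc2cn(-c3cccc(C#N)c3)nn2)c1CC=C(C)C` gives 35300 nM

In a functional assay on HCT-116 cells (Homo sapiens) for cytotoxicity, read by MTT assay, with a stated time of 24 h (on this read-out higher numbers stand for weaker inhibition and lower numbers for stronger inhibition), compound 2 stands at the higher of the two numbers, its nearest neighbour being compound 1, whose number is lower by a gap beyond the scatter. Compound 3 `COc1ccc(/C=C\C(=O)O)c(OCc2cn(-c3ccccc3)nn2)c1CC=C(C)C` follows from compound 2 by one change: hydrogen in place of cyano on an aromatic carbon. For the measured compounds named here, no comparable pair has been measured, so the size of the step is open; a modest change, most likely none beyond the scatter, is expected in a 1.1-fold higher number from compound 2 to compound 3 (0.05 log units; within the scatter). Compound 3 is accordingly estimated at 40000 nM, within a range from 15000 nM to 110000 nM.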

Compound 3, half-maximal inhibitory concentration: 26000 nM
Beside the measured number, compound 3's estimate is 1.5-fold (0.19 log units) above it, within the range that was stated.
By their numbers in this assay, from the lowest: compounds 1, 3 and 2 (each within the scatter of the next, the first and the last beyond it).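

In this assay, hydrogen in place of cyano gives a 1.4-fold lower number from compound 2 to compound 3 (0.13 log units; within the scatter) and so leaves no readable effect of the nitrile on this aromatic carbon. Hydrogen in place of benzamido gives a 1.6-fold higher number from compound 1 to compound 3 (0.20 log units; within the scatter) and likewise stays inside the scatter, so the phenyl compound cannot be separated from either substituted compound, even though those two lie apart. Nothing available explains these results. From the compounds shown here alone, what remains open is whether an amine or a carboxylic acid on this aromatic ring would move the number beyond the scatter from compound 3.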